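A few compounds are considered here, and "the series" means these few. Any claim that something is new, unique, unknown or untested is made for them only; others in the source may bear on it.

Measured so far:
Compound 1 `Nc1nc(-c2ccccc2)nc2sc(-c3ccccc3)nc12` in a functional assay on CHO cells for antagonist activity at adenosine receptor A2b (Homo sapiens), read by cAMP accumulation, with a stated time of 10 min (a lower number here means a stronger inhibitor, a higher number a weaker inhibitor), gives > 30000 nM, a limit of the assay and not a number.
Compound 2 `COc1ccc(-c2nc(N)c3nc(-c4ccccc4)sc3n2)cc1` gives > 30000 nM in this assay, likewise a limit and not a number.

Going by the values given here, compound 1 therefore stands only at a limit in this assay, with no number of its own; the same holds for the one further value shown, so that (the limit of > 30000 nM in this assay, at which 2 of the 2 values shown sit). Among the compounds with values here, the one measured step, a step that the two limits leave unreadable from compound 1 to compound 2, is accordingly unreadable in size: both ends sit at the limit, and nothing can be said of its direction.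

Compound 3 `Nc1nc(-c2ccccc2)nc2sc(-c3ccco3)nc12` differs from compound 1 in a single place: furan-2-yl in place of phenyl on an aromatic carbon. No measured step touches this kind of exchange, and the only step shown, from compound 1 to compound 2, gives no size at all. There is thus no basis for expecting a step of any readable size or direction in this assay from the exchange of phenyl for furan-2-yl.

On that footing, compound 3 is expected to give about 40000 nM in this assay, with a range from 10000 nM to 200000 nM, most likely again only as a limit. The expected step that the limit leaves unreadable from compound 1 to compound 3 is therefore essentially none beyond the scatter.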

Compound 3, half-maximal inhibitory concentration: > 30000 nM
Compound 3 ended at the assay's limit; the forecaster's own chance of this, stated with the estimate: 75%; the middle value is on the limit's open side.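

The exchange of phenyl for furan-2-yl gives no readable step between compound 1 and compound 3 in this assay, because both compounds end at a limit of the assay and not at a number: the limit of > 30000 nM in this assay, at which 3 of the 3 values shown sit. The compounds shown leave open whether either group makes any difference to inhibition in this assay, and what change to the shared core would bring a value within reach.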